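This account rests on a few compounds, and the source may have more. Where it says the series, first, only, none or still open, it means among the compounds named here.

Measured so far:
compound 1 `CCOC(=O)c1c(-c2cccc(Oc3ccccc3)c2)[nH]c2cc(F)cc(F)c2c1=O` — > 21500 nM
compound 2 `CCOC(=O)c1c(-c2cccc(OC(F)(F)F)c2)[nH]c2cc(F)cc(F)c2c1=O` — > 21500 nM
compound 3 `CCOC(=O)c1c(-c2cccc(Oc3ccccc3)c2)[nH]c2cc(OC)c(F)cc2c1=O` — > 21500 nM

All three values come from an ADME assay on Raji cells (Homo sapiens) for cytotoxicity, read by luminescence, with a stated time of 72 h; on this read-out lower numbers stand for an effect already at smaller amounts and higher numbers for an effect only at larger amounts of compound. For compound 1 the value > 21500 nM is a limit of the assay, not a number. Compound 2 likewise gives only a limit, > 21500 nM. Compound 3 too stops at a limit, > 21500 nM.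

Compound 2 differs from compound 1 by trifluoromethyl in place of phenyl on an oxygen on an aromatic ring. The step that this change made is a step that the two limits leave unreadable from compound 1 to compound 2; its size cannot be read because of the limit of > 21500 nM in this assay, at which 3 of the 3 values shown sit. The two values show no more than that both compounds lie beyond the reach of this assay.

Compound 4 `CCOC(=O)c1c(-c2cccc(OC(F)(F)F)c2)[nH]c2cc(OC)c(F)cc2c1=O` has not yet been measured. It differs from compound 3 by trifluoromethyl in place of phenyl on an oxygen on an aromatic ring, which is the same change, at the same kind of place, as between compound 1 and compound 2. How the core of compound 3 differs from the core of compound 1 is not broken down here.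

In this assay the step expected from this change is a step that the limit leaves unreadable from compound 3 to compound 4, set beside the earlier one, and it rests on (the limit of > 21500 nM in this assay, at which 3 of the 3 values shown sit). Compound 4 is therefore estimated at 30000 nM, within an expected range from 15000 nM to 100000 nM, and the assay is expected to report once more only a limit rather than a number.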

Compound 4, half-maximal effective concentration: > 21500 nM
Compound 4: no number, only a limit (the forecaster's own chance of this, stated with the estimate: 85%); the middle value does not contradict the limit.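

Going by these compounds alone, compound 3 and compound 4 both stop at a limit rather than a number, so the change from phenoxy to trifluoromethoxy between them gives no step that can be read: the limit of > 21500 nM in this assay, at which 4 of the 4 values shown sit.

The compounds shown leave open whether that change of group, or the difference between the two cores, alters the read-out at all, and at what concentration any of the four compounds would begin to show an effect.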